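Benzyloxy in Place of Dimethylamino on a Shared Core

The source may hold more compounds than are shown below. What is called first, only, known or untested is meant among the compounds shown, and "the series" means these compounds.

Compound 1 `CCOC(=O)CCCCCOc1cccc(CN(C(=O)c2ccc(-c3cccc(N(C)C)c3)cc2)C(C)C)c1` sits only at a limit of the assay: in an ADME assay on HepG2 cells (Homo sapiens) for cytotoxicity, read by CellTiter-Glo and resazurin assay, with a stated time of 72 h (on this read-out higher numbers stand for an effect only at larger amounts of compound and lower numbers for an effect already at smaller amounts), compound 1 gives > 26000 nM, a limit rather than a number. Compound 2 `CCOC(=O)CCCCCOc1cccc(CN(C(=O)c2ccc(-c3ccc(C(C)=O)s3)cc2)C(C)C)c1`, with 5-acetylthiophen-2-yl in place of 3-(dimethylamino)phenyl on an aromatic carbon, gives > 26000 nM in this assay, again a limit. The step that the two limits leave unreadable from compound 1 to compound 2 cannot be read because of the limit of > 26000 nM in this assay, at which 2 of the 2 values shown sit. Compound 3 `CCOC(=O)CCCCCOc1cccc(CN(C(=O)c2ccc(-c3cccc(OCc4ccccc4)c3)cc2)C(C)C)c1` carries benzyloxy in place of dimethylamino on an aromatic carbon. Among the measured compounds shown here, no measured step gives a readable size, so compound 3 is expected to stay at the limit as well, with a step that the limit leaves unreadable from compound 1 to compound 3 of no size beyond the scatter. Compound 3 is estimated at 30000 nM, within 15000 nM to 60000 nM.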

Compound 3, half-maximal effective concentration: > 26000 nM
Compound 3 ended at the assay's limit; the forecaster's own chance of this, stated with the estimate: 80%; the middle value is on the limit's open side.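

Compound 1 and compound 3 both sit at a limit of this assay, so no size can be read for the step between them: the limit of > 26000 nM in this assay, at which 3 of the 3 values shown sit. The compounds shown leave open at what concentration, if any, an effect would appear in this assay for any of the three.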